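This account rests on a few compounds, and the source may have more. Where it says the series, first, only, none or still open, it means among the compounds named here.

Measured compounds:
compound 1 `Nc1nc(N)nc(-c2cccc(Br)c2)n1`: 96%
compound 2 `Nc1nc(N)nc(-c2cccc(Cl)c2)n1`: 100%
compound 3 `Nc1nc(N)nc(-c2cc(Cl)ccc2Br)n1`: 81%

In a functional assay on the whole organism with Rattus norvegicus as the target, at a dose of 20 mg/kg by the intraperitoneal route (a higher number here means more inhibition at the dose given (going by the name of the read-out), a lower number less inhibition), compound 2 gives 100%, the top number of the three; compound 1 sits close to it, with a gap that is a number 4 percentage points higher from compound 1 to compound 2 (within the scatter), so the two cannot be ranked against each other. Compound 3 stands further off, the gap being a number 19 percentage points lower from compound 2 to compound 3 (beyond the scatter).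

The next compound, compound 4 `Nc1nc(N)nc(-c2cccc([N+](=O)[O-])c2)n1`, differs from compound 2 in one place: nitro in place of chloro on an aromatic carbon. Among the compounds with values here, no measured step swaps chloro for nitro. The one-place steps on hand are the halogen exchange from compound 1 to compound 2, which stayed within the scatter, and the added bromo from compound 2 to compound 3, which cost a modest amount beyond it. The read-out of compound 2 already sits at the ceiling, so any movement can only be downward or nil. The expectation for compound 4 is a small loss, a number 10 percentage points lower from compound 2 to compound 4 (within the scatter), that may or may not exceed the scatter. Compound 4 is therefore estimated at 90%, with a range from 70% to 100%.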

Compound 4, a percentage reported as inhibition, in the whole organism at one dose (the size of the read-out at that dose, not a potency): 85%
Compound 4: the middle estimate sits 5 percentage points above what was measured, within the range that was stated.
By their numbers in this assay, from the lowest: compounds 3 and 4 (each within the scatter of the next); then compounds 1 and 2 (each within the scatter of the next).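

In this assay, nitro in place of chloro on this aromatic carbon gives a number 15 percentage points lower from compound 2 to compound 4 (beyond the scatter), and nitro in place of bromo gives a number 11 percentage points lower from compound 1 to compound 4 (beyond the scatter). Within the data shown here, the exchange between the two halogens stayed within the scatter, so the earlier compounds showed no response at this position; these steps show that the read-out does respond to the group placed there, though only modestly, as compound 4 still gives 85%. Nothing at hand accounts for the loss on going from either halogen to nitro.

As far as these compounds go, whether an amine, a carboxylic acid or a methoxy group on the same aromatic carbon would hold the read-out or lower it further remains open. All these numbers come from a single dose, so they give the size of the effect at that dose and leave the potency of the compounds undetermined.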